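The source may report more compounds than this note shows. Statements on the series, on what has been measured and on what is new or still open speak of the compounds shown alone.

Working notes on the series. In a functional assay on A375-C5 cells (Homo sapiens) for inhibition, read by sulforhodamine B assay, with a stated time of 48 h (on this read-out higher numbers stand for weaker inhibition of growth and lower numbers for stronger inhibition of growth), compound 1 `COC(=O)c1sc2cc(Nc3ccccc3Br)cnc2c1N` gives 34100 nM. Compound 2 `COC(=O)c1sc2cc(Nc3ccccn3)cnc2c1N` reaches only the assay limit, > 150000 nM in this assay. Compound 3 `COC(=O)c1sc2cc(Nc3cccnc3)cnc2c1N` likewise sits at a limit, > 150000 nM in this assay. Compound 3 therefore stands, together with one other value of the set, at the limit of > 150000 nM in this assay, at which 2 of the 3 values shown sit, and only compound 1 yields a number. The steps of an at least 4.3-fold higher number from compound 1 to compound 2 (0.64 log units; beyond the scatter) and an at least 4.3-fold higher number from compound 1 to compound 3 (0.64 log units; beyond the scatter) both read as a loss of growth inhibition, while the step that the two limits leave unreadable from compound 2 to compound 3 cannot be sized. Compound 4 `COC(=O)c1sc2cc(Nc3ncccn3)cnc2c1N` differs from compound 3 by pyrimidin-2-yl in place of pyridin-3-yl on a nitrogen on an aromatic ring. Since pyridin-2-yl and pyridin-3-yl in place of 2-bromophenyl both ended at the limit, compound 4 is expected to stay there too, with an expected step of a number no higher from compound 3 to compound 4 (the limit leaves the size open) not readable beyond the scatter. Compound 4 is thus estimated at 150000 nM, within 40000 nM to 500000 nM.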

Compound 4, concentration for 50% growth inhibition: > 150000 nM
Compound 4 was reported as a limit (the forecaster's own chance of this, stated with the estimate: 75%); the middle value lies on the limit itself.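

Pyrimidin-2-yl, a six-membered aromatic ring with 2 hetero atoms, also fails to restore growth inhibition at this nitrogen, giving an at least 4.3-fold higher number from compound 1 to compound 4 (0.64 log units; beyond the scatter) in this assay. The steps among compound 2, compound 3 and compound 4 cannot be read, so these rings cannot be ranked. Compound 4 gives only a limit, and the series now shows: the limit of > 150000 nM in this assay, at which 3 of the 4 values shown sit.

Only the 2-bromophenyl of compound 1 gives a number here. As far as these compounds go, whether unsubstituted phenyl, or a phenyl bearing chlorine or methoxy in place of bromine, would keep growth inhibition remains open.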